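The source may report more compounds than this note shows. Statements on the series, on what has been measured and on what is new or still open speak of the compounds shown alone.

Measured compounds:
compound 1 `CC(C)C(c1ccc(-c2ccc3cccc(F)c3c2)[nH]c1=O)N1CCCCS1(=O)=O` — 14 nM
compound 2 `CC(C)C(Cc1ncc[nH]1)c1ccc(-c2ccc3cccc(F)c3c2)[nH]c1=O` — 11 nM
compound 3 `CC(C)C(Nc1nnc[nH]1)c1ccc(-c2ccc3cccc(F)c3c2)[nH]c1=O` — 22 nM

In an assay on CHO cells for displacement of a labelled ligand from prostaglandin E2 receptor EP3 subtype (Homo sapiens), read by radioligand binding (a higher number here means a weaker inhibitor, a lower number a stronger inhibitor), compound 3 has the highest of the three numbers, but the steps of a 1.6-fold higher number from compound 1 to compound 3 (0.20 log units; within the scatter) and a 2.0-fold higher number from compound 2 to compound 3 (0.30 log units; within the scatter) both lie within the scatter, so no order among these three can be claimed. Compound 4 `CC(C)C(c1ncco1)c1ccc(-c2ccc3cccc(F)c3c2)[nH]c1=O` differs from compound 3 by 1,3-oxazol-2-yl in place of (4H-1,2,4-triazol-3-yl)amino on a saturated chain carbon bound to an aromatic carbon and a saturated chain carbon. Among the compounds with values here, every measured step so far exchanged the group at this same place, and each of them, a 1.3-fold lower number from compound 1 to compound 2 (0.10 log units; within the scatter), a 1.6-fold higher number from compound 1 to compound 3 (0.20 log units; within the scatter) and a 2.0-fold higher number from compound 2 to compound 3 (0.30 log units; within the scatter), stayed within the scatter. On that basis the expected step of a 1.4-fold lower number from compound 3 to compound 4 (0.14 log units; within the scatter) is small, with no direction beyond the scatter. Compound 4 is therefore estimated at 16 nM, with a likely range from 7 nM to 40 nM.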

Compound 4, inhibition constant: 24 nM
Compound 4: middle estimate off by 1.5-fold (0.18 log units), on the low side; low and high end bracket the measured number.
By their numbers in this assay, from the lowest: compounds 2, 1, 3 and 4 (each within the scatter of the next, the first and the last beyond it).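

In this assay, 1,3-oxazol-2-yl carries no hydrogen-bond donors, yet swapping it in for (4H-1,2,4-triazol-3-yl)amino leaves the number within the scatter (a 1.1-fold higher number from compound 3 to compound 4 (0.04 log units; within the scatter)), so at this position those donors are not needed to keep the binding seen here. The exchange for the six-membered ring of compound 1 also stays within the scatter (a 1.7-fold higher number from compound 1 to compound 4 (0.23 log units; within the scatter)). Within the data shown here, the first step at this position beyond the scatter is a modest one (a 2.2-fold higher number from compound 2 to compound 4 (0.34 log units; beyond the scatter)), and nothing measured here explains it. On these data alone, whether an amine, a carboxylic acid or a longer chain would be accepted here stays open.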